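The source may report more compounds than this note shows. Statements on the series, on what has been measured and on what is new or still open speak of the compounds shown alone.

Notes on the series in a functional assay on the whole organism (blood, strain Wistar-Okamoto) with Rattus norvegicus as the target, with a stated time of 5 days; on this read-out lower numbers stand for an effect already at smaller amounts and higher numbers for an effect only at larger amounts of compound. Compound 1 `CC(C)(C)/N=C(\NC#N)Nc1ccccn1` returns only a limit of the assay, > 20 mg/kg. Compound 2 `CCC(C)(C)N/C(=N\C=O)Nc1cccnc1` likewise returns only a limit in this assay, > 20 mg/kg. For the measured compounds named here, both results sit at the limit of > 20 mg/kg in this assay, at which 2 of the 2 values shown sit, so compound 2 stands at the limit and not at a number: nothing in this assay places it higher or lower than compound 1, and no pair of measured compounds differs in a single place, so no measured step exists to lean on. The unmeasured compound, compound 3 `CCC(C)(C)N/C(=N\c1ncccn1)Nc1cccnc1`, differs from compound 2 in one place: pyrimidin-2-yl in place of formyl on a double-bonded nitrogen. With two limits as the only results, the data give no direction for this change in this assay. The expectation is that the step that the limit leaves unreadable from compound 2 to compound 3 stays small, without a settled direction, and that compound 3 may again return only a limit. For compound 3 the estimated minimum effective dose in this assay is 25 mg/kg, with an expected range from 10 mg/kg to 60 mg/kg.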

Compound 3, minimum effective dose: > 35 mg/kg
Compound 3 was reported as a limit (the forecaster's own chance of this, stated with the estimate: 70%); middle value at least 1.4-fold (0.14 log units) away from the limit.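

Compound 2 and compound 3 both return only limits of the assay, so no step can be read between them. The compounds shown leave open whether pyrimidin-2-yl in place of formyl on a double-bonded nitrogen changes the minimum effective dose at all, and in which direction any such change would run.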